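The compounds below may be only part of what the source reports. "The series", "measured", "known", "first", "only" and "open" are said of these compounds alone.

In a functional assay on a cell-free system (Platelet, plasma, Oryctolagus cuniculus) for inhibition, with a stated time of 5 min, at 37 degrees C (a lower number here means a stronger inhibitor, a higher number a weaker inhibitor), compound 1 (`CCOC(=O)/C=C/c1ccc(OC)cc1OC(=O)c1nc(C)c(C)nc1C`) gives 28200 nM and compound 2 (`CCOC(=O)/C=C/c1cc(OC)ccc1OC(=O)c1nc(C)c(C)nc1C`) gives 196000 nM as the higher number of the two, a gap beyond the scatter. Compound 3 (`CCOC(=O)/C=C/c1ccccc1OC(=O)c1nc(C)c(C)nc1C`) differs from compound 2 by hydrogen in place of methoxy on an aromatic carbon with hydrogen in place of methoxy on an aromatic carbon. Within the data shown here, no measured step covers this change. Compound 2 at 196000 nM stands at the weak end of the pair, so a move toward compound 1 at 28200 nM is expected. The estimated change is a 2.5-fold lower number from compound 2 to compound 3 (0.39 log units; beyond the scatter) in this assay toward a lower number and moderate in size. For compound 3 the estimated value is 80000 nM within an expected range from 25000 nM to 250000 nM in this series.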

Compound 3, half-maximal inhibitory concentration: 110000 nM
Estimate against measurement, compound 3: 1.4-fold (0.14 log units) below, and the stated range covers the measured number.
By their numbers in this assay, from the lowest: compound 1; then compounds 3 and 2 (each within the scatter of the next).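

In this assay, hydrogen in place of the methoxy meta to a 2-(ethoxycarbonyl)ethenyl group and para to a large group gives a 1.8-fold lower number from compound 2 to compound 3 (0.25 log units; within the scatter) and so does not separate methoxy from hydrogen at this position. The same exchange for the methoxy of compound 1 gives a 3.9-fold higher number from compound 1 to compound 3 (0.59 log units; beyond the scatter) and does separate them, so the outcome of this change depends on where the methoxy stands. No evidence on the reason is available. Still open, going by these compounds, is whether a hydroxyl, an amine or a longer alkoxy chain at either position would change the number beyond the scatter.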